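This account rests on a few compounds, and the source may have more. Where it says the series, first, only, none or still open, it means among the compounds named here.

Compounds measured so far:
- compound 1, `CCCNC(=O)c1cccc2nc(OCC)n(Cc3ccc(-c4ccccc4-c4nnn[nH]4)cc3)c12`, in an assay on isolated protein for inhibition of NEDD8-activating enzyme E1 regulatory subunit (Homo sapiens), read by Western blot, with stated times of 10 min and 30 min, tested at 25 uM (on this read-out higher numbers stand for more inhibition at the one concentration tested (going by the name of the read-out) and lower numbers for less inhibition), compound 1 gives 32.6%
- compound 2, `CCOc1nc2cccc(C(=O)NCCCOC)c2n1Cc1ccc(-c2ccccc2-c2nnn[nH]2)cc1`, in this assay compound 2 gives 27.9%

Both measured compounds share the same core and differ only in the chain on the amide-type nitrogen. The step of a number 4.7 percentage points lower from compound 1 to compound 2 (within the scatter) shows that adding a methoxy to that chain left the inhibition within the scatter, so compound 2 and compound 1 cannot be told apart on these numbers.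

The unmeasured compound 3, `CCOc1nc2cccc(C(=O)N[C@H]3CC[C@H](C(=O)OC)CC3)c2n1Cc1ccc(-c2ccccc2-c2nnn[nH]2)cc1`, again changes only the group on that nitrogen: 4-(methoxycarbonyl)cyclohexyl in place of 3-methoxypropyl on an amide-type nitrogen. Within the data shown here, the only step that bears on it, a number 4.7 percentage points lower from compound 1 to compound 2 (within the scatter), was a small change at the same position and gave no movement beyond the scatter. The present change is larger, swapping a chain for a ring carrying an ester, so a wider uncertainty is warranted, but no direction is suggested by the data.

Compound 3 is therefore expected to give about 30%, with a range from 12% to 48%, an expected step of a number 2.1 percentage points higher from compound 2 to compound 3 (within the scatter).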

Compound 3, a percentage reported as inhibition, at one concentration (the size of the read-out at that concentration, not a potency): 28.6%
For compound 3 the middle estimate is 1.4 percentage points above the measured one; the range from low to high includes it.
By their numbers in this assay, from the lowest: compounds 2, 3 and 1 (each within the scatter of the next).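

In this assay, putting 4-(methoxycarbonyl)cyclohexyl in place of 3-methoxypropyl on the amide-type nitrogen gives a number 0.7 percentage points higher from compound 2 to compound 3 (within the scatter) and putting it in place of propyl gives a number 4 percentage points lower from compound 1 to compound 3 (within the scatter) on the same scale. The earlier pair showed only that a small addition to an open chain left the number within the scatter; these steps show the same for a swap to a far larger group with a six-membered carbon ring, so compounds 1, 2 and 3 cannot be told apart here. No measurement on hand offers any explanation for this flat result.

As far as these compounds go, all three groups on this nitrogen carry no net charge, so it remains open whether an amine or a carboxylic acid there would move the number beyond the scatter. The effect of the two defined stereocentres of compound 3 also remains open, since no other arrangement of that ring is among these compounds.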